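The compounds below may be only part of what the source reports. "The series", "measured", "known", "first", "only" and "open" are said of these compounds alone.

Measured so far:
compound 1 `CNc1ncnc2c1ncn2Cc1ccccc1C(F)(F)F` — 20 mg/kg
compound 2 `CN(C)c1ncnc2c1ncn2Cc1c(F)cccc1Cl` — 5 mg/kg
compound 3 `CCCNc1ncnc2c1ncn2Cc1ccccc1F` — 5.1 mg/kg

In a functional assay on the whole organism with Rattus norvegicus as the target, in the maximal electroshock model (a higher number here means that more compound is needed for the effect, a lower number that less compound is needed), compound 1 gives 20 mg/kg, compound 2 gives 5 mg/kg and compound 3 gives 5.1 mg/kg. Compound 3 stands second highest of the three numbers; its nearest neighbour is compound 2, within the scatter, and its furthest is compound 1, beyond the scatter. Among the measured compounds shown here, no two of the measured compounds differ in one place only, so no single step in this assay is available from the measured set.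

Compound 4 `Fc1ccccc1Cn1cnc2c(NC3CC3)ncnc21` is not yet measured. It differs from compound 3 in one place:

cyclopropyl in place of propyl on a nitrogen on an aromatic ring

For the measured compounds named here, no measured pair shows what this change does in this assay. The three measured compounds span a modest range, and a small step, toward a lower number or none beyond the scatter, is expected here. Compound 4 is therefore estimated at about 4 mg/kg in this assay, with a range from 1.5 mg/kg to 12 mg/kg. The step this estimate means, a 1.3-fold lower number from compound 3 to compound 4 (0.11 log units; within the scatter), is expected to stay within the scatter.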

Compound 4, dose for half-maximal effect: 5 mg/kg
For compound 4 the middle estimate is 1.3-fold (0.10 log units) below the measured one; low and high end bracket the measured number.
By their numbers in this assay, from the lowest: compounds 2, 4 and 3 (each within the scatter of the next); then compound 1.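

Among the compounds shown here, this is the first comparison that differs in one place only: in this assay cyclopropyl in place of propyl on a nitrogen on an aromatic ring gives a 1.0-fold lower number from compound 3 to compound 4 (0.01 log units; within the scatter) and thus no distinction between the two groups. On this nitrogen, the open chain and the three-membered ring of carbon, each of 3 carbon atoms, are interchangeable in this read-out with the rest of the structure held fixed. Nothing measured here bears on why the two groups read alike.

Going by these compounds, whether a longer chain such as hexyl, or a hydroxyethyl group, on the same nitrogen would move the number beyond the scatter stays open. Also open, on these data alone, is whether the same exchange reads alike with a different substituent on the benzyl ring.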